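Swapping methyl for ethoxy on the shared core

The source may report more compounds than this note shows. Statements on the series, on what has been measured and on what is new or still open speak of the compounds shown alone.

Among the compounds with values here, in a functional assay on the whole organism (strain Wistar) for inhibition, with Rattus norvegicus as the target (a lower number here means that less compound is needed, a higher number that more compound is needed for the effect), compound 1 `Cc1ccc2c(O)c(C#N)c(=O)oc2c1` gives 52.4 umol/kg, the highest of the three numbers measured so far. Compound 2 `Cc1cc2oc(=O)c(C#N)c(O)c2cc1C` gives 15.2 umol/kg, and compound 3 `CCc1cc2c(O)c(C#N)c(=O)oc2cc1C` gives 10.1 umol/kg. The unmeasured compound 4 `CCOc1ccc2c(O)c(C#N)c(=O)oc2c1` differs from compound 1 in one place, with ethoxy in place of methyl on an aromatic carbon.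

Within the data shown here, no measured step makes this swap, so the evidence is indirect. Two modest steps replace a hydrogen on an aromatic carbon: a 3.4-fold lower number from compound 1 to compound 2 (0.54 log units; beyond the scatter) with methyl, and a 5.2-fold lower number from compound 1 to compound 3 (0.72 log units; beyond the scatter) with ethyl. Both keep the original methyl, which compound 4 loses. The third step, a 1.5-fold lower number from compound 2 to compound 3 (0.18 log units; within the scatter), lengthens the added chain and stays within the scatter. Together these show that a small carbon group added to compound 1 can lower the number, but they say nothing direct about an oxygen-linked group replacing the methyl. Only a small lowering is therefore expected, and its direction is uncertain. The estimated step is a 1.9-fold lower number from compound 1 to compound 4 (0.27 log units; within the scatter), which is not far beyond the usual scatter at best. For compound 4 the expected value is 28 umol/kg, with an estimated range from 9 umol/kg to 80 umol/kg.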

Compound 4, dose for half-maximal effect: 15.1 umol/kg
Compound 4: the middle estimate sits 1.9-fold (0.27 log units) above what was measured, and the stated range covers the measured number.
By their numbers in this assay, from the lowest: compounds 3, 4 and 2 (each within the scatter of the next); then compound 1.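

The methyl of compound 1 is not needed for the effect in this assay at this position, since ethoxy in its place on the aromatic carbon gives a 3.5-fold lower number from compound 1 to compound 4 (0.54 log units; beyond the scatter) and so moves the number beyond the scatter. The earlier steps shown here that lowered the number all kept this methyl and added a carbon group elsewhere, whereas this step removes it and brings in a larger, oxygen-linked group that counts as a hydrogen-bond acceptor, which methyl does not. Nothing available here explains why the number falls with this change.

From the compounds shown here alone, it remains open whether the oxygen link or the extra size of the group matters more, and a methoxy group or a propyl group in the same place would help to separate the two. Also open, going by these compounds, are how a longer oxygen-linked chain such as butoxy or a different kind of group such as an amine would behave here, and whether ethoxy would give a similar step on a core that carries the extra carbon groups of compound 2 or compound 3.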